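The source may hold more compounds than are shown below. What is called first, only, known or untested is meant among the compounds shown, and "the series" means these compounds.

In a functional assay on HepG2 cells (Homo sapiens) for cytotoxicity, read by MTT assay, with a stated time of 72 h (a lower number here means a stronger inhibitor, a higher number a weaker inhibitor), compound 1 `CNC(=O)c1cc(Oc2ccc(C3=NNC(c4ccc(F)cc4Cl)C3)cc2)ccn1` gives 11500 nM. Among the measured compounds shown here, compound 3 `CNC(=O)c1cc(Oc2ccc(C3=NNC(c4ccc(OC)c(OC)c4OC)C3)cc2)ccn1` gives 15700 nM, a value within the usual scatter of the one for compound 1. Compound 2 `CNC(=O)c1cc(Oc2ccc(C3=NNC(c4ccc([N+](=O)[O-])cc4)C3)cc2)ccn1` gives > 50000 nM, which is a limit of the assay and not a number. Those are the only results so far for this series, and compound 1 holds the lowest of the numbers, though not by a margin beyond the scatter.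

The next compound is compound 4 `CNC(=O)c1cc(Oc2ccc(C3=NNC(c4cccc(Cl)c4Cl)C3)cc2)ccn1`, in which 2,3-dichlorophenyl takes the place of 2-chloro-4-fluorophenyl on a saturated ring carbon: 2,3-dichlorophenyl in place of 2-chloro-4-fluorophenyl on a saturated ring carbon. For the measured compounds named here, one measured step bears on this position, an at least 4.3-fold higher number from compound 1 to compound 2 (0.63 log units; beyond the scatter), where 4-nitrophenyl came in. That step was beyond the scatter, but compound 4 carries no 4-nitrophenyl and simply trades one chlorine-bearing phenyl for another. Going by the values given here, no measured step makes such a trade, so no change beyond the scatter is expected, and the estimated step is small: a 1.2-fold lower number from compound 1 to compound 4 (0.06 log units; within the scatter). The estimate for compound 4 is 10000 nM, with an expected range of 5000 nM to 22000 nM.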

Compound 4, half-maximal inhibitory concentration: 4990 nM
Compound 4: the middle estimate sits 2.0-fold (0.30 log units) above what was measured; measured number below the stated range.
By their numbers in this assay, from the lowest: compound 4; then compounds 1 and 3 (each within the scatter of the next). At a limit, above all of these: compound 2.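

In this assay, this position turns out to respond to more than the change to 4-nitrophenyl: trading one chlorine-bearing phenyl for another, with the same count of heavy atoms, gives a 2.3-fold lower number from compound 1 to compound 4 (0.36 log units; beyond the scatter). The other new step, an at least 10-fold lower number from compound 2 to compound 4 (1.00 log units; beyond the scatter), gives only a bound and not an exact size, because compound 2 stands at a limit of the assay and not at a number: the limit of > 50000 nM in this assay, at which 1 of the 4 values shown sits.

The change from compound 1 to compound 4 removes a fluorine and adds a chlorine, and the two groups also carry their halogens in different places, so the compounds shown cannot say which of these matters. Groups such as 2-chlorophenyl, 2,4-dichlorophenyl or a phenyl bearing an amine or a carboxylic acid remain open at this position, as does whether any of them would lower the number further.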